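Cytotoxicity limits in the series and one further analogue

A few compounds are considered here, and "the series" means these few. Any claim that something is new, unique, unknown or untested is made for them only; others in the source may bear on it.

Measured so far, in a toxicity assay on MT2 cells (Homo sapiens) for cytotoxicity, read by XTT assay, with a stated time of 4 days; on this read-out lower numbers stand for higher toxicity in this test and higher numbers for lower toxicity in this test:
compound 1, `Cc1nc(C)c([C@H](OC(C)(C)C)C(=O)O)c(N2CCC(C)(C)CC2)c1-c1ccc(Cc2ccccc2)cc1`: >= 20000 nM, a limit of the test.
compound 2, `Cc1nc(C)c([C@H](OC(C)(C)C)C(=O)O)c(N2CCC(C)(C)CC2)c1-c1ccc(SCCc2ccc(F)cc2)cc1`: >= 32000 nM, a limit of the test.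
compound 3, `Cc1nc(C)c([C@H](OC(C)(C)C)C(=O)O)c(N2CCC(C)(C)CC2)c1-c1ccc(OCCc2ccccn2)cc1`: >= 25000 nM, a limit of the test.

Compound 1 stands only at a limit in this assay; the three values are all limits, (the limit of >= 20000 nM in this assay, at which 1 of the 3 values shown sits), the limit of >= 25000 nM in this assay, at which 1 of the 3 values shown sits, and (the limit of >= 32000 nM in this assay, at which 1 of the 3 values shown sits). The steps a step that the two limits leave unreadable from compound 1 to compound 2, a step that the two limits leave unreadable from compound 1 to compound 3 and a step that the two limits leave unreadable from compound 2 to compound 3 therefore cannot be sized. Compound 4, `Cc1nc(CCOc2ccc(-c3c(C)nc(C)c([C@H](OC(C)(C)C)C(=O)O)c3N3CCC(C)(C)CC3)cc2)cs1`, carries the change (2-(2-methyl-1,3-thiazol-4-yl)ethoxy in place of benzyl on an aromatic carbon). The measured steps bearing on it are all unreadable, so no step beyond the scatter is expected in this assay, and a further limit is the likely outcome. Compound 4 is estimated at 30000 nM, within 15000 nM to 100000 nM, which would mean an expected step that the limit leaves unreadable from compound 1 to compound 4.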

Compound 4, half-maximal cytotoxic concentration: >= 25000 nM
Compound 4: only a limit was reported; the forecaster's own chance of this, stated with the estimate: 85%; the middle value lies beyond the limit too.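

Compound 4, like compound 1, compound 2 and compound 3, gives only a limit in this assay, and no step among these compounds can be read. The compounds shown leave open at what concentration any of them becomes cytotoxic, and whether the exchanged groups differ at all in this assay.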